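Swapping methyl for iodo on a shared selenium-sugar core

The source may report more compounds than this note shows. Statements on the series, on what has been measured and on what is new or still open speak of the compounds shown alone.

Compound 1 has the structure `Cc1cn(C2[Se][C@H](CO)[C@@H](O)[C@@H]2N=[N+]=[N-])c(=O)[nH]c1=O`. Tested in a functional assay on T47D cells (Homo sapiens) for cytotoxicity, read by sulforhodamine B assay (on this read-out lower numbers stand for stronger inhibition and higher numbers for weaker inhibition), compound 1 gives > 100000 nM, which is a limit of the assay rather than a number. Two close relatives carry a different group on the same aromatic carbon. Compound 2, `[N-]=[N+]=N[C@@H]1C(n2cc(F)c(=O)[nH]c2=O)[Se][C@H](CO)[C@H]1O`, bears fluoro there. In this assay compound 2 also gives > 100000 nM, again a limit. Compound 3, `[N-]=[N+]=N[C@@H]1C(n2cc(Cl)c(=O)[nH]c2=O)[Se][C@H](CO)[C@H]1O`, bears chloro. In this assay compound 3 gives > 100000 nM, a limit as well.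

The new compound, compound 4, is `[N-]=[N+]=N[C@@H]1C(n2cc(I)c(=O)[nH]c2=O)[Se][C@H](CO)[C@H]1O`. It differs from compound 1 as follows: iodo in place of methyl on an aromatic carbon. The three measured steps that bear on this exchange are a step that the two limits leave unreadable from compound 1 to compound 2, a step that the two limits leave unreadable from compound 1 to compound 3 and a step that the two limits leave unreadable from compound 2 to compound 3. None of them can be read, since all three values rest at the limit of > 100000 nM in this assay, at which 3 of the 3 values shown sit. Nothing among these compounds separates one group on that carbon from another, so no direction can be drawn for iodo.

The expectation for compound 4 in this assay is therefore a value no better than the measured ones, estimated at 150000 nM with a range from 50000 nM to 500000 nM. The step from compound 1 to compound 4 is expected to be a step that the limit leaves unreadable from compound 1 to compound 4.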

Compound 4, half-maximal inhibitory concentration: > 100000 nM
Compound 4 was reported as a limit; the forecaster's own chance of this, stated with the estimate: 80%; the middle value does not contradict the limit.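

Compound 4 gives a limit in this assay rather than a number, as do compound 1, compound 2 and compound 3, so none of the steps from these three compounds to compound 4 can be read: the limit of > 100000 nM in this assay, at which 4 of the 4 values shown sit.

The compounds shown leave open whether any group on that aromatic carbon could give a readable value in this assay, and how large the differences between these groups are.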